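The compounds below may be only part of what the source reports. "The series", "measured", "known", "first", "only" and "open" are said of these compounds alone.

Measured so far:

compound 1 `CCC(c1ccccc1)c1nc(-c2ccc(Cl)cc2)c(CC(=O)O)s1`: 190 nM
compound 2 `O=C(O)Cc1sc(C(c2ccc(F)cc2)c2ccc(F)cc2)nc1-c1ccnc(N2CCCC2)c1`: 230 nM
compound 3 `O=C(O)Cc1sc(C2COc3ccccc3O2)nc1-c1ccc(Cl)cc1`: 500 nM

Three compounds have numbers in an in vitro assay on HEK385-7 cells for displacement of a labelled ligand from prostaglandin D2 receptor 2 (Homo sapiens); a higher number here means a weaker inhibitor, a lower number a stronger inhibitor. Compound 2 stands second highest of the three. Compound 1 lies nearest to it, within the usual scatter, so the two cannot be ordered on these data. Compound 3 gives the higher number, and that gap to compound 2 lies beyond the scatter.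

Compound 4 `CN(C)c1cc(-c2nc(C(c3ccc(F)cc3)c3ccc(F)cc3)sc2CC(=O)O)ccn1` differs from compound 2 in one place:

dimethylamino in place of pyrrolidin-1-yl on an aromatic carbon

Going by the values given here, no pair of measured compounds isolates this change, so nothing shows what it does. Both the leaving and the entering group carry one hydrogen-bond acceptor and no donor; the entering group is smaller and has no ring. Among the compounds with values here, with no comparable step on record, the expectation is a small step in this assay, not beyond the scatter, in either direction. Compound 4 is therefore estimated at 300 nM, with a range from 120 nM to 800 nM. The estimated step is a 1.3-fold higher number from compound 2 to compound 4 (0.12 log units; within the scatter), essentially flat.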

Compound 4, half-maximal inhibitory concentration: 380 nM
Compound 4: middle estimate off by 1.3-fold (0.10 log units), on the low side; low and high end bracket the measured number.
By their numbers in this assay, from the lowest: compounds 1, 2, 4 and 3 (each within the scatter of the next, the first and the last beyond it).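

In this assay, going by these compounds alone, this pair gives the first step that isolates a single change: a 1.7-fold higher number from compound 2 to compound 4 (0.22 log units; within the scatter). At this place, on an aromatic carbon next to the ring nitrogen, the ring of pyrrolidin-1-yl can give way to the smaller, open dimethylamino group without a step beyond the scatter, so the ring itself is not shown to be needed for the number in this assay. Nothing measured on these compounds accounts for the small step, and its direction cannot be taken as real.

On these data alone, whether a morpholine ring or an unsubstituted amine at this place would stay within the scatter of compound 2 remains open. Also open, as far as these compounds go, is whether the same change would read alike on a compound with a different group elsewhere on the core.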